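A few compounds are considered here, and "the series" means these few. Any claim that something is new, unique, unknown or untested is made for them only; others in the source may bear on it.

Working notes on the series. In an ADME assay on microsomes from liver (Homo sapiens) for metabolic stability (on this read-out lower numbers stand for slow clearance and higher numbers for fast clearance), compound 1 `Cc1cc2ncccc2cc1Nc1ncc2c(n1)n(C1CCOCC1)c(=O)n2C` gives 30 mL.min-1.g-1, while compound 2 `Cc1cc2nnccc2cc1Nc1ncc2c(n1)n(C1CCOCC1)c(=O)n2C` gives 14 mL.min-1.g-1. Compound 1 therefore has the higher of the two measured numbers, and the gap to compound 2 lies beyond the usual scatter.

Compound 3 `Cc1cc2ncccc2cc1Nc1ncc2c(n1)n([C@H]1CCN(C3COC3)C1)c(=O)n2C` has not yet been measured. It keeps the core of compound 1 and changes the group on an aromatic nitrogen of a five-membered aromatic ring, with 1-(oxetan-3-yl)pyrrolidin-3-yl in place of oxan-4-yl on an aromatic nitrogen. The entering group also carries one defined stereocentre.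

Going by the values given here, no two measured compounds differ in one place only, so the data give no direct precedent for the size of this change. The expected step of a 1.2-fold higher number from compound 1 to compound 3 (0.07 log units; within the scatter) in this assay is small, staying within the scatter and leaning slightly towards faster clearance, with real uncertainty in both directions. For compound 3 the estimated value is 35 mL.min-1.g-1, with an expected range of 16 mL.min-1.g-1 to 75 mL.min-1.g-1.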

Compound 3, intrinsic clearance in microsomes in the Homo sapiens assay: 33 mL.min-1.g-1
Estimate against measurement, compound 3: 1.1-fold (0.03 log units) above, and the stated range covers the measured number.
By their numbers in the Homo sapiens assay, from the lowest: compound 2; then compounds 1 and 3 (each within the scatter of the next).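

Going by these compounds alone, the change at this position, from oxan-4-yl to 1-(oxetan-3-yl)pyrrolidin-3-yl on an aromatic nitrogen, gives the series its first direct step in the Homo sapiens assay, a 1.1-fold higher number from compound 1 to compound 3 (0.04 log units; within the scatter), and the earlier compounds offered no such pair. A larger group with two rings is thus accommodated here with no clearance difference that can be told from the scatter. The same change does register in a physicochemical assay for lipophilicity, read by HPLC, using the shake flask method, measured as octanol-water partition, at pH 7.4 (a higher number here means a more lipophilic compound, a lower number a more polar compound), where compound 1 gives 2.5 and compound 3 gives 1.5, compound 3 clearly being the more polar of the pair, and for this one pair the two read-outs part ways, with the distribution coefficient moving while the clearance number does not: the measured distribution coefficient of compound 1, 2.5, and of compound 3, 1.5, a number 1.00 log units lower (beyond the scatter)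

The entering group brings in an oxetane, a pyrrolidine ring nitrogen and a defined stereocentre all at once, and this single pair cannot assign either result to any one of them; a simple N-methylpyrrolidin-3-yl or a hydroxyl-bearing cyclohexyl group at the same nitrogen would help to separate these parts. As far as these compounds go, whether the step carries over to the core of compound 2, which has the lowest number in the Homo sapiens assay, also stays open.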